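A Fluorophenyl Variant on the Hydroxyacyl Side Chain

The source may hold more compounds than are shown below. What is called first, only, known or untested is meant among the compounds shown, and "the series" means these compounds.

Compound 1, `COC(C)(C)[C@@H](O)C(=O)N1N=CC[C@H]1C(=O)NCc1cc(Cl)ccc1-n1cnnn1`, is known in an ADME assay on liver for metabolic stability, with Liver microsome (Homo sapiens) as the target, read by LC-MS, using microsomes (a higher number here means faster removal of the compound, a lower number slower removal), only by the assay limit of < 12 mL.min-1.g-1; that figure is a limit, not a measured number. Compound 2, `CC(C)(C)[C@@H](O)C(=O)N1OCC[C@H]1C(=O)NCc1cc(Cl)ccc1-n1cnnn1`, likewise gives only the limit < 12 mL.min-1.g-1 in this assay. Compound 3, `CC(C)(C)C[C@@H](O)C(=O)N1OCC[C@H]1C(=O)NCc1cc(Cl)ccc1-n1cnnn1`, returns the limit < 12 mL.min-1.g-1 in this assay as well. For the measured compounds named here, the single step between measured compounds, a step that the two limits leave unreadable from compound 2 to compound 3, cannot be read because of the limit of < 12 mL.min-1.g-1 in this assay, at which 3 of the 3 values shown sit.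

Compound 4, `O=C(NCc1cc(Cl)ccc1-n1cnnn1)[C@@H]1CC=NN1C(=O)[C@H](O)c1ccccc1F`, has not yet been measured in this assay. It differs from compound 1 by 2-fluorophenyl in place of 1-methoxy-1-methylethyl on a saturated chain carbon bound to a carbonyl carbon and an oxygen on a saturated carbon. Going by the values given here, no measured step bears on this exchange: the one recorded step swaps neopentyl for tert-butyl, both saturated groups, and no measured compound carries an aromatic group on the saturated chain carbon bound to a carbonyl carbon and an oxygen on a saturated carbon. Because (the limit of < 12 mL.min-1.g-1 in this assay, at which 3 of the 3 values shown sit), the measured compounds set no direction for the move from 1-methoxy-1-methylethyl to 2-fluorophenyl.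

Compound 4 is therefore expected to sit near the low end of this assay, with an estimated step of an at least 1.2-fold higher number from compound 1 to compound 4 (0.09 log units; that floor lies within the scatter). The estimate for compound 4 in this assay is 15 mL.min-1.g-1, with an expected range from 5 mL.min-1.g-1 to 45 mL.min-1.g-1.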

Compound 4, intrinsic clearance in microsomes: 16 mL.min-1.g-1
The estimate for compound 4 lay 1.1-fold (0.03 log units) below the measured number; low and high end bracket the measured number.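

Compound 4 gives 16 mL.min-1.g-1 in this assay, the only number among the compounds shown that is not a limit, and it puts an aromatic ring on record on a saturated chain carbon bound to a carbonyl carbon and an oxygen on a saturated carbon, where compound 1 carries a saturated group. Exchanging 1-methoxy-1-methylethyl for 2-fluorophenyl gives an at least 1.3-fold higher number from compound 1 to compound 4 (0.12 log units; that floor lies within the scatter), so this change is known only as a floor, and that floor does not by itself separate the two compounds. Neither the full size of this step nor the step from compound 2 to compound 3 can be read, because the values rest on a limit: the limit of < 12 mL.min-1.g-1 in this assay, at which 3 of the 4 values shown sit.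

Still open, going by these compounds, is how a plain phenyl or a pyridine ring would read at this place on the core of compound 4, and so whether the fluorine has any bearing on the number. Also open, on these data alone, is where an amine or a carboxylic acid on the same group would fall in this assay.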